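Oxime ether to phenyl imine on a coumarin-type core

The source may report more compounds than this note shows. Statements on the series, on what has been measured and on what is new or still open speak of the compounds shown alone.

Compound 1 `CO/N=C/c1ccc2ccc(=O)oc2c1`: 99.9%
Compound 2 `O=c1ccc2ccc(/C=N/O)cc2o1`: 98.5%

In a functional assay for inhibition of serine protease 1 (Homo sapiens), tested at 1 mM (a higher number here means a stronger effect of the compound at the concentration tested, a lower number a weaker effect), compound 1 gives 99.9% and compound 2 gives 98.5%. Within the data shown here, the only measured step, a number 1.4 percentage points lower from compound 1 to compound 2 (within the scatter), leaves the two compounds inseparable, so compound 2 stands level with compound 1 near complete inhibition.

Compound 3 `O=c1ccc2ccc(/C=N/c3ccccc3)cc2o1` differs from compound 2 by phenyl in place of hydroxy on a double-bonded nitrogen. Among the measured compounds shown here, no measured step touches a double-bonded nitrogen; the hydrogen-for-methyl step on oxygen gives no guide to an exchange of this kind. For the measured compounds named here, the expectation is therefore only that compound 3 stays high, with a wider margin for a drop: the estimated step of a number 10.5 percentage points lower from compound 2 to compound 3 (beyond the scatter) is modest. Compound 3 is expected at 88% in this assay, within 55% to 100%.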

Compound 3, a percentage reported as inhibition, at one concentration (the size of the read-out at that concentration, not a potency): 97.6%
For compound 3 the middle estimate is 9.6 percentage points below the measured one, and the stated range covers the measured number.
By their numbers in this assay, from the lowest: compounds 3, 2 and 1 (each within the scatter of the next).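

On the double-bonded nitrogen, phenyl in place of hydroxy gives a number 0.9 percentage points lower from compound 2 to compound 3 (within the scatter) in this assay, and phenyl in place of methoxy gives a number 2.3 percentage points lower from compound 1 to compound 3 (within the scatter). The earlier compounds shown here varied only the group on the oxygen, whereas this exchange removes that oxygen, with the hydrogen-bond donor and acceptor of hydroxy, and brings in an aromatic ring without a separable change in this read-out. No available evidence bears on this result.

All three compounds lie near complete inhibition at a single concentration, so any differences between them in the size of the effect at other concentrations remain unresolved. Also open, going by these compounds, is whether an amine or a carboxylic acid on the phenyl ring would keep this level of inhibition.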